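The compounds below may be only part of what the source reports. "The series", "measured", "known", "first", "only" and "open" are said of these compounds alone.

Of the compounds shown here, three have been measured so far in a functional assay, read by Griess assay, with a stated time of 2.5 h (a lower number here means a stronger inhibitor, a higher number a weaker inhibitor), and they do not separate. Compound 1 (`COc1ccc(C(=O)/C=C/c2cc(OC)c(OC)cc2OC)cc1`) reads 2.07 ug/mL there, while compound 2 (`COc1cc(OC)c(-c2cc(=O)c3ccc(O)cc3o2)cc1OC`) reads 2.27 ug/mL and compound 3 (`COc1cc(OC)c(OC)cc1/C=C/C(=O)c1cc(Cc2ccccc2)cc(Cc2ccccc2)c1`) reads 2.09 ug/mL in the same test. Compound 1 therefore stands level with both others, since all three numbers lie within the usual scatter of one another.

Still unmeasured is compound 4 (`COc1cc(OC)c(OC)cc1/C=C/C(=O)c1ccc(C)cc1`), which has methyl in place of methoxy on an aromatic carbon, para to a large group (methyl in place of methoxy on an aromatic carbon). The same difference, cut one bond further out, reads 4-methoxyphenyl to 4-methylphenyl.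

Among the measured compounds shown here, no measured pair isolates this change, and the data give no direct guide to its size. They do show that compound 2 at 2.27 ug/mL and compound 3 at 2.09 ug/mL differ from compound 1 by much more than one group, yet remain within the scatter of it. On that basis, no step beyond the scatter is expected in this assay, and any drift towards a higher number should be slight. The estimated step is a 1.1-fold higher number from compound 1 to compound 4 (0.05 log units; within the scatter) and it stays within the scatter. For compound 4 the expected value is 2.3 ug/mL with an estimated range from 1.2 ug/mL to 4.5 ug/mL until a measurement is available.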

Compound 4, half-maximal inhibitory concentration: 2.18 ug/mL
Compound 4: middle estimate off by 1.1-fold (0.02 log units), on the high side, and the stated range covers the measured number.
By their numbers in this assay, from the lowest: compounds 1, 3, 4 and 2 (each within the scatter of the next).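

Among the compounds shown here, compound 4 gives the first comparison that differs in one place: in this assay, putting methyl in place of methoxy on an aromatic carbon, para to a large group, gives a 1.1-fold higher number from compound 1 to compound 4 (0.02 log units; within the scatter) and so leaves the two compounds indistinguishable. The earlier compounds shown here differed from compound 1 in more than one group, so they could not show what this position alone contributes, whereas this pair shows that the 4-methoxyphenyl and 4-methylphenyl forms read alike, even though the methoxy group counts one hydrogen-bond acceptor and the methyl group none. Nothing measured alongside this result bears on why the two forms read alike.

Going by these compounds, what remains open is whether any group at this position can produce a step beyond the scatter in this assay, for example an amine, a carboxylic acid or a longer chain such as butoxy. On these data alone, it is also open whether the same exchange of methyl for methoxy would read the same way at the other methoxy groups of the shared core, since this single pair speaks only for the one position.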